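The source may hold more compounds than are shown below. What is called first, only, known or untested is meant among the compounds shown, and "the series" means these compounds.

Compounds measured so far:
- compound 1 `COc1nc2nc(C(=O)c3ccccc3)cn2c(C)c1CC1CC1`: 10 mg/kg
- compound 2 `CCc1c(OC)nc2nc(C(=O)c3ccccc3)cn2c1C`: 2 mg/kg
- compound 3 `CCc1c(OC)nc2nc(C(=O)c3ccccc3)cn2c1CC`: 2 mg/kg

All three were tested in a functional assay on the whole organism with Rattus norvegicus as the target; on this read-out higher numbers stand for an effect only at larger amounts of compound and lower numbers for an effect already at smaller amounts. On this read-out compound 2 stands level with compound 3, and together the two give the lowest numbers of the set; the furthest from them is compound 1, whose number is higher by a 5.0-fold lower number from compound 1 to compound 2 (0.70 log units; beyond the scatter) when read back to compound 2. The step from compound 2 to compound 3, methyl in place of hydrogen on a saturated chain carbon bound to an aromatic carbon, gave no change at the digits printed from compound 2 to compound 3 (within the scatter).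

Compound 4 `COc1nc2nc(C(=O)c3ccccc3)cn2c(C)c1OC` has not yet been tested. It differs from compound 2 in one place: methoxy in place of ethyl on an aromatic carbon. Among the compounds with values here, of the measured steps, only the one from compound 1 to compound 2 touches this aromatic carbon, and there a smaller saturated chain gave a lower number. Within the data shown here, no measured step swaps a carbon chain for a group with an oxygen, so the direction of the new step is not settled by the data. With a group of the same size as the ethyl that leaves, a step within the scatter is expected, and the estimate for compound 4 is 3 mg/kg, between 1 mg/kg and 10 mg/kg, which means an expected step of a 1.5-fold higher number from compound 2 to compound 4 (0.18 log units; within the scatter).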

Compound 4, minimum effective dose: 5 mg/kg
For compound 4 the middle estimate is 1.7-fold (0.22 log units) below the measured one, and the stated range covers the measured number.
By their numbers in this assay, from the lowest: compounds 2 and 3 (each within the scatter of the next); then compounds 4 and 1 (each within the scatter of the next).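

In this assay, methoxy in place of ethyl on this aromatic carbon gave a 2.5-fold higher number from compound 2 to compound 4 (0.40 log units; beyond the scatter), so a group with the same count of heavy atoms, but with an oxygen and a hydrogen-bond acceptor, does not match the ethyl here. Methoxy in place of cyclopropylmethyl gave a 2.0-fold lower number from compound 1 to compound 4 (0.30 log units; within the scatter), which means the methoxy and cyclopropylmethyl groups cannot be told apart on this read-out, while the ethyl group stands apart from both with the lowest number of the three, each of its two steps lying beyond the scatter. Nothing available explains why ethyl stands apart from these two groups at this position.

The compounds shown leave open how the number would respond to a propyl chain, a chlorine atom or an amine on this aromatic carbon, so it is unclear whether ethyl is a narrow best fit or one point on a broader trend. On these data alone, it also remains open whether methoxy here would give the same result with an ethyl group in place of the methyl group that sits ortho to it.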